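The source may hold more compounds than are shown below. What is called first, only, known or untested is meant among the compounds shown, and "the series" means these compounds.

Series notes, cytotoxicity on a shared core.

Compound 1 `O=C(Nc1ccc(Br)cc1)c1cn(-c2ccccc2)nc1-c1ccccc1` is the reference. In a functional assay on HCT-116 cells (Homo sapiens) for cytotoxicity, read by MTT assay, with a stated time of 48 h (a higher number here means a weaker inhibitor, a lower number a stronger inhibitor), compound 1 gives 4470 nM. Compound 2 `COc1ccc(NC(=O)c2cn(-c3ccccc3)nc2-c2ccccc2)cc1` differs from compound 1 by methoxy in place of bromo on an aromatic carbon. In this assay compound 2 gives 1350 nM, so the change made a step of a 3.3-fold lower number from compound 1 to compound 2 (0.52 log units; beyond the scatter). Compound 3 `O=C(Nc1ccc(Br)cc1)c1cn(-c2ccccc2)nc1-c1ccc([N+](=O)[O-])cc1` carries a different core from compound 1; the two cores differ by nitro in place of hydrogen on an aromatic carbon. In this assay compound 3 gives 4080 nM, which is a step of a 1.1-fold lower number from compound 1 to compound 3 (0.04 log units; within the scatter), so the two cores cannot be told apart on this read-out.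

Compound 4 `COc1ccc(NC(=O)c2cn(-c3ccccc3)nc2-c2ccc([N+](=O)[O-])cc2)cc1` is not yet measured. It differs from compound 3 by methoxy in place of bromo on an aromatic carbon. Among the compounds with values here, this is the same change as the one from compound 1 to compound 2: the group that leaves, the group that enters and the place are the same, word for word, and the only difference between the two pairs lies in the core, which itself gave a step within the scatter. Among the four compounds this change occurs twice in all.

The expectation for compound 4 is therefore a step of about the same size as the measured one, namely a 3.1-fold lower number from compound 3 to compound 4 (0.50 log units; beyond the scatter), because the earlier change gave a 3.3-fold lower number from compound 1 to compound 2 (0.52 log units; beyond the scatter) on a core that differs from that of compound 3 only by a change that in turn gave a 1.1-fold lower number from compound 1 to compound 3 (0.04 log units; within the scatter). On that basis compound 4 is estimated at 1300 nM in this assay, with a plausible range from 600 nM to 2800 nM. The estimate rests on a single earlier instance of the change, so the range is kept wide.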

Compound 4, half-maximal inhibitory concentration: 1020 nM
Compound 4: the middle estimate sits 1.3-fold (0.11 log units) above what was measured, within the range that was stated.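

In this assay, methoxy in place of bromo on the core carrying the nitro group gives a 4.0-fold lower number from compound 3 to compound 4 (0.60 log units; beyond the scatter), and this step agrees with the one on the core of compound 1: the same change on two cores in this assay, a 3.3-fold lower number (0.52 log units; beyond the scatter) from compound 1 to compound 2 and a 4.0-fold lower number (0.60 log units; beyond the scatter) from compound 3 to compound 4, 1.2-fold (0.08 log units) apart, within the scatter of two such steps. Nitro in place of hydrogen, now read with methoxy rather than bromo on the other aromatic ring, gives a 1.3-fold lower number from compound 2 to compound 4 (0.12 log units; within the scatter), so the two cores remain indistinguishable on this read-out with either group, and the two changes can be read here without either one altering the size of the other: the same change on two cores in this assay, a 1.1-fold lower number (0.04 log units; within the scatter) from compound 1 to compound 3 and a 1.3-fold lower number (0.12 log units; within the scatter) from compound 2 to compound 4, 1.2-fold (0.08 log units) apart, within the scatter of two such steps. Within the data shown here, this shows that the change carries across these two cores, but it rests on only two instances on cores that cannot be told apart themselves, so it does not show that the step would hold on a core that differs more, nor why methoxy gives the lower number.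

As far as these compounds go, it remains open whether a group such as a hydroxyl, an amine or a carboxylic acid in the place of bromo would follow the same pattern. From the compounds shown here alone, it is equally open whether the step would persist with an amine or a chlorine in place of the nitro group, or on any cell line other than this one.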